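The source may hold more compounds than are shown below. What is called first, only, known or untested is meant among the compounds shown, and "the series" means these compounds.

Compound 1 `COc1ccc2[nH]cc(-c3nc(C(=O)Nc4cc(OC)c(OC)c(OC)c4)cs3)c2c1`: 94300 nM
Compound 2 `O=C(Nc1ccccc1)c1csc(-c2c[nH]c3ccccc23)n1`: > 100000 nM

For the measured compounds named here, compound 1 `COc1ccc2[nH]cc(-c3nc(C(=O)Nc4cc(OC)c(OC)c(OC)c4)cs3)c2c1` is one of only two compounds tested in a functional assay on PC-3 cells (Homo sapiens) for cytotoxicity, read by MTT assay, with a stated time of 48 h, in the absence of a further agent; a lower number here means a stronger inhibitor, a higher number a weaker inhibitor. In this assay, going by the values given here, compound 1 gives 94300 nM, the sole numerical value among the two. Compound 2 `O=C(Nc1ccccc1)c1csc(-c2c[nH]c3ccccc23)n1` reaches only a limit of the assay in this assay, namely > 100000 nM. Among the compounds with values here, compound 1 therefore stands as the one measured number beside (the limit of > 100000 nM in this assay, at which 1 of the 2 values shown sits).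

Compound 3 `COc1cc(NC(=O)c2csc(-c3c[nH]c4ccc(Br)cc34)n2)cc(OC)c1OC` differs from compound 1 in a single place: bromo in place of methoxy on an aromatic carbon. Within the data shown here, no measured pair shows what such a swap does in this assay. Since both measured compounds sit at or near the top of the tested range, the step from compound 1 to compound 3 is expected to be small, a 1.1-fold lower number from compound 1 to compound 3 (0.05 log units; within the scatter), with no clear direction beyond the scatter. Compound 3 is thus expected to give about 85000 nM, within 30000 nM to 250000 nM, with a fair chance that it too only reaches a limit.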

Compound 3, half-maximal inhibitory concentration: > 100000 nM
Compound 3 gave a limit, no number (the forecaster's own chance of this, stated with the estimate: 40%); middle value at least 1.1-fold (0.07 log units) from the limit.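

Putting bromo in place of methoxy on this aromatic carbon gives, in this assay, an at least 1.0-fold higher number from compound 1 to compound 3 (0.02 log units; that floor lies within the scatter). Compound 3 gives > 100000 nM, which is a limit and not a number, so the step has a floor but no known full size. This first change read at this position brings no gain in strength, and the series now gathers at the top of the tested range: the limit of > 100000 nM in this assay, at which 2 of the 3 values shown sit.

Still open, from the compounds shown here alone, is whether another group on this aromatic carbon, such as a hydroxyl, an amine or a carboxylic acid, would bring the number into a clearly measurable range. Also open, going by these compounds, is how plain hydrogen at this place would read with the rest of compound 1 kept unchanged.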